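Short Nitrile Chain in Place of a Sulfonamide Aryl Arm

This account rests on a few compounds, and the source may have more. Where it says the series, first, only, none or still open, it means among the compounds named here.

The three measured compounds:
Compound 1, `CC(C)(N)C(=O)N[C@H](COCc1ccccc1)c1nnnn1CC#N`, gives 4170 nM in an assay on isolated protein for displacement of a labelled ligand from growth hormone secretagogue receptor type 1 (Homo sapiens), with a stated time of 1 h; a lower number here means a stronger inhibitor, a higher number a weaker inhibitor.
Compound 2, `CC(C)(N)C(=O)N[C@H](COCc1ccccc1)c1nnn(Cc2cccc(NS(C)(=O)=O)c2)n1`, gives > 5000 nM in this assay; this is a limit of the assay, not a number.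
Compound 3, `CC(C)(N)C(=O)N[C@H](COCc1ccccc1)c1nnn(CC2Cc3ccccc3N2S(C)(=O)=O)n1`, gives > 5000 nM in this assay; this too is a limit.

Compound 2 therefore stands at the limit of > 5000 nM in this assay, at which 2 of the 3 values shown sit, so only a weakest-possible value is known for it. Compound 4, `CC(C)(N)C(=O)N[C@H](COCc1ccccc1)c1nnn(CCCCC#N)n1`, differs from it by 3-cyanopropyl in place of 3-(methanesulfonamido)phenyl on a saturated chain carbon bound to an aromatic nitrogen. Compound 1, which carries the other short nitrile substituent, does give a number, 4170 nM. A move off the limit is thus expected: an at least 1.2-fold lower number from compound 2 to compound 4 (0.09 log units; that floor lies within the scatter) is the step expected in this assay. Compound 4 is thus estimated at 4000 nM, within the range 1500 nM to 12000 nM.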

Compound 4, inhibition constant: > 5000 nM
Compound 4: a limit, no number; the forecaster's own chance of this, stated with the estimate: 35%; middle value at least 1.2-fold (0.09 log units) from the limit.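

Compound 2 and compound 4 both give only a limit in this assay, not a number, and no step can be read between them. As far as these compounds go, whether 3-cyanopropyl in place of 3-(methanesulfonamido)phenyl changes the true value at all remains open.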